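Removing One Methyl From The Amide Aryl Ring

The source may report more compounds than this note shows. Statements on the series, on what has been measured and on what is new or still open speak of the compounds shown alone.

Compound 1, `Cc1cnc(Nc2ccc(C(=O)Nc3c(C)cccc3C)cc2)nc1-c1ccc(OC(F)(F)F)cc1`, gives 1.3 nM in an assay on NIH3T3 cells for inhibition of Sonic hedgehog protein (Mus musculus), read by a luciferase reporter, with a stated time of 48 h; a higher number here means a weaker inhibitor, a lower number a stronger inhibitor.
Compound 3, `Cc1cnc(Nc2ccc(C(=O)Nc3c(C)cccc3C)cc2)nc1-c1ccccc1`, gives 1.3 nM in this assay.
Compound 2, `Cc1ccc(-c2nc(Nc3ccc(C(=O)Nc4c(C)cccc4C)cc3)ncc2C)cc1`, is reported as > 500 nM in this assay.

The value of compound 2 is a limit of the assay rather than a measured number (the limit of > 500 nM in this assay, at which 1 of the 3 values shown sits). Compounds 1 and 3 sit level at the digits given, no change at the digits printed from compound 1 to compound 3 (within the scatter), with hydrogen in place of trifluoromethoxy on an aromatic carbon separating them. Compound 2 differs from compound 3 by hydrogen in place of methyl on an aromatic carbon, and that step is large: an at least 380-fold lower number from compound 2 to compound 3 (2.58 log units; beyond the scatter). Compound 1 and compound 2 differ by trifluoromethoxy in place of methyl on an aromatic carbon, and the step between them is an at least 380-fold higher number from compound 1 to compound 2 (2.58 log units; beyond the scatter).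

Compound 4, `Cc1ccccc1NC(=O)c1ccc(Nc2ncc(C)c(-c3ccc(OC(F)(F)F)cc3)n2)cc1`, has not yet been measured in this assay. It differs from compound 1 by hydrogen in place of methyl on an aromatic carbon. Among the measured compounds shown here, this is the same kind of change as the one from compound 2 to compound 3, but not the same: there the place was para to a large group, whereas here it is ortho to a large group and meta to a methyl group, on a different ring of the shared core. The large step seen from compound 2 to compound 3 is therefore not a direct guide. Starting from compound 1 at 1.3 nM, only a modest step is expected, a 3.8-fold higher number from compound 1 to compound 4 (0.59 log units; beyond the scatter). Compound 4 is expected to give about 5 nM, estimated to lie between 1 nM and 50 nM.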

Compound 4, half-maximal inhibitory concentration: 1 nM
Estimate against measurement, compound 4: 5.0-fold (0.70 log units) above; low and high end bracket the measured number.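

Putting hydrogen in place of methyl on the amide aryl ring, which turns the 2,6-dimethylphenyl group into 2-methylphenyl, gives a 1.3-fold lower number from compound 1 to compound 4 (0.11 log units; within the scatter) in this assay. This swap of methyl for hydrogen therefore cannot be carried through the series as one fixed step, for the methyl leaves a different ring of the shared core in each pair, and the two results clearly part: the same change on two cores in this assay, an at least 380-fold lower number (2.58 log units; beyond the scatter) from compound 2 to compound 3 and a 1.3-fold lower number (0.11 log units; within the scatter) from compound 1 to compound 4, at least 290-fold (2.47 log units) apart, beyond the scatter of two such steps The two pairs do not tell why the steps differ, whether the ring or the surrounding structure decides the outcome, or how large the earlier step truly is, since compound 2 is known only through a limit: the limit of > 500 nM in this assay, at which 1 of the 4 values shown sits.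

The compounds shown leave open what happens when the remaining methyl of the 2-methylphenyl group also gives way to hydrogen, and whether compound 3, which lacks the trifluoromethoxy group, would tolerate the same change on its amide aryl ring as compound 1 does. They also leave open how a chlorine atom, a methoxy group or an amine would fare at the aromatic carbon that carries trifluoromethoxy in compound 1 and methyl in compound 2.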